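Cyclic amine replacement in the shared core

The compounds below may be only part of what the source reports. "The series", "measured", "known", "first", "only" and "open" are said of these compounds alone.

Compound 1 `CCCNCc1cc(-c2c(C(=O)NCC)noc2-c2cc(C(C)C)c(O)cc2O)on1` carries the propylamino group on the shared core; in a functional assay on A2780 cells (Homo sapiens) for inhibition (on this read-out higher numbers stand for weaker inhibition and lower numbers for stronger inhibition), compound 1 stands at "not determined" (no result reported), so no number fixes the starting point of this step. Two close neighbours on the same core are measured: compound 2 `C=CNCc1cc(-c2c(C(=O)NCC)noc2-c2cc(C(C)C)c(O)cc2O)on1` gives 43 nM in this assay, and compound 3 `CCNC(=O)c1noc(-c2cc(C(C)C)c(O)cc2O)c1-c1cc(CN2CCCCC2)no1` gives 62 nM. Compound 4 `CCNC(=O)c1noc(-c2cc(C(C)C)c(O)cc2O)c1-c1cc(CN2CCCC2)no1` is the unmeasured target; its difference from compound 1 is pyrrolidin-1-yl in place of propylamino on a saturated chain carbon bound to an aromatic carbon. For the measured compounds named here, one measured step bears on it, since it also closes an open-chain amine into a ring at the same place: a 1.4-fold higher number from compound 2 to compound 3 (0.16 log units; within the scatter). That step is within the scatter, and nothing else in the series speaks against a similar outcome here. Compound 4 is therefore expected to land close to compound 3 and compound 2, with no step beyond the scatter in this assay. Compound 4 is estimated at 55 nM, with a likely range from 25 nM to 120 nM.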

Compound 4, half-maximal inhibitory concentration: 55 nM
Estimate against measurement, compound 4: no gap at the digits printed; measured number inside the range.
By their numbers in this assay, from the lowest: compounds 2, 4 and 3 (each within the scatter of the next).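

In this assay, pyrrolidin-1-yl in place of piperidin-1-yl gives a 1.1-fold lower number from compound 3 to compound 4 (0.05 log units; within the scatter), so the read-out does not separate these two ring sizes on a saturated chain carbon bound to an aromatic carbon. The second ring amine also stays level with the open-chain vinylamino group, with a 1.3-fold higher number from compound 2 to compound 4 (0.11 log units; within the scatter), so compounds 2, 3 and 4 form one group within the scatter. Nothing available explains this flat response at the position.

With compound 1 at "not determined" (no result reported), the step from propylamino to pyrrolidin-1-yl cannot be read. The compounds shown leave open whether a morpholine ring, a larger azepane ring or an unsubstituted primary amine at this place would stay in the same range.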